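A few compounds are considered here, and "the series" means these few. Any claim that something is new, unique, unknown or untested is made for them only; others in the source may bear on it.

Measured so far in a functional assay on SGC-7901 cells (Homo sapiens) for antiproliferative activity, read by MTT assay, with a stated time of 24 h; a higher number here means a weaker inhibitor, a lower number a stronger inhibitor:
- Compound 1 `Cc1ccccc1NNC(=O)c1cccc(NS(=O)(=O)c2cnc(O)nc2O)c1`: > 20000 nM
- Compound 2 `O=C(NNc1ccccc1Cl)c1cccc(NS(=O)(=O)c2cnc(O)nc2O)c1`: 2270 nM
- Compound 3 `O=C(NNc1ccccc1F)c1cccc(NS(=O)(=O)c2cnc(O)nc2O)c1`: > 20000 nM

Compound 3 stands at > 20000 nM, which is a limit of the assay and not a number. Compound 1 also carries a limit, > 20000 nM. The series therefore sits largely at one boundary, with the limit of > 20000 nM in this assay, at which 2 of the 3 values shown sit. Compound 2 alone gives a number, 2270 nM.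

Compound 4 `Cc1ccccc1C(=O)NNC(=O)c1cccc(NS(=O)(=O)c2cnc(O)nc2O)c1` differs from compound 3 on an amine nitrogen whose other neighbour is an amide-type nitrogen: (2-methylphenyl)carbonyl in place of 2-fluorophenyl on an amine nitrogen. Within the data shown here, no measured step makes this exact change, so the evidence is indirect. Chloro in place of methyl gave an at least 8.8-fold lower number from compound 1 to compound 2 (0.94 log units; beyond the scatter), and fluoro in place of chloro gave an at least 8.8-fold higher number from compound 2 to compound 3 (0.94 log units; beyond the scatter). Both lie beyond the scatter, and both involve compound 2. The remaining comparison is a step that the two limits leave unreadable from compound 1 to compound 3.

Among the measured compounds shown here, compound 4 has no chloro, so the one change that produced a number in this assay does not carry over. No clear step in either direction is expected, and the expected step is a number no higher from compound 3 to compound 4 (the limit leaves the size open). Compound 4 is estimated at about 20000 nM, with an expected range of 6000 nM to 60000 nM.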

Compound 4, half-maximal inhibitory concentration: > 20000 nM
Compound 4 was reported as a limit (the forecaster's own chance of this, stated with the estimate: 60%); the middle value sits exactly at the limit.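

Among these compounds, the earlier compounds varied only one group on the phenyl ring attached to the amine nitrogen, whereas compound 4 alters what sits on that nitrogen, with (2-methylphenyl)carbonyl in place of the aryl group. Among the compounds shown here, measured against compound 2, the only compound with a number, this change gives an at least 8.8-fold higher number from compound 2 to compound 4 (0.94 log units; beyond the scatter), so in this assay the new group does not keep the activity seen with 2-chlorophenyl. The steps to compound 4 from compound 1 and from compound 3 cannot be read, as each joins two limits of the assay, and the series now rests even more heavily on one boundary: the limit of > 20000 nM in this assay, at which 3 of the 4 values shown sit.

As far as these compounds go, whether a (2-chlorophenyl)carbonyl group on this nitrogen would bring back a number remains open, as does whether a bromo group in place of the chloro of compound 2 would hold the activity. For the compounds shown here, with only one true number, how far compound 1, compound 3 and compound 4 differ from one another also stays unknown.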